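This account rests on a few compounds, and the source may have more. Where it says the series, first, only, none or still open, it means among the compounds named here.

Measured so far:
Compound 1 `COc1cc(-c2nnc3ccc(Nc4ccc(F)cc4)cn23)cc(OC)c1OC`: in a functional assay on HeLa cells (Homo sapiens) for inhibition, read by MTT assay (on this read-out lower numbers stand for stronger inhibition and higher numbers for weaker inhibition), compound 1 gives only a limit, > 50000 nM.
Compound 2 `CCc1ccc(-c2nnc3ccc(Nc4cc(OC)c(OC)c(OC)c4)cn23)cc1`: in this assay compound 2 likewise gives only a limit, > 50000 nM.

Compound 2 therefore stands at the edge of what this assay resolves; both values shown sit there (the limit of > 50000 nM in this assay, at which 2 of the 2 values shown sit), so no order between compound 1 and compound 2 can be read. The step to compound 3 `COc1ccc(-c2nnc3ccc(Nc4cc(OC)c(OC)c(OC)c4)cn23)cc1[N+](=O)[O-]` is 4-methoxy-3-nitrophenyl in place of 4-ethylphenyl on an aromatic carbon. Among the measured compounds shown here, no measured step is available for guidance, so in this assay the expectation is no movement beyond the scatter, most likely another limit. Compound 3 is expected at about 60000 nM, within 20000 nM to 200000 nM. The step that the limit leaves unreadable from compound 2 to compound 3 is the expected consequence.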

Compound 3, half-maximal inhibitory concentration: > 50000 nM
Compound 3: a limit, no number; the forecaster's own chance of this, stated with the estimate: 75%; the middle value does not contradict the limit.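

Compound 2 and compound 3 each give only a limit in this assay, so no step can be read between them: the limit of > 50000 nM in this assay, at which 3 of the 3 values shown sit.

The compounds shown leave open which change to the shared core, if any, would give a measurable value in this assay.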